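The source may report more compounds than this note shows. Statements on the series, on what has been measured and on what is new or still open speak of the compounds shown alone.

Compound 1 `COc1cc(C(=O)/C=C/c2ccc(O)cc2)cc(OC)c1OC` and compound 2 `COc1cc(C(=O)/C=C/c2ccc(O)c(O)c2)cc(OC)c1OC` share a core and differ at a single aromatic position. In a functional assay on COLO 205 cells (Homo sapiens) for inhibition, read by MTT assay, with a stated time of 48 h (on this read-out lower numbers stand for stronger inhibition and higher numbers for weaker inhibition), compound 1 gives 29700 nM, while compound 2 gives 19800 nM. The step of a 1.5-fold lower number from compound 1 to compound 2 (0.18 log units; within the scatter) lies within the scatter, so the two numbers cannot be ordered. Within the data shown here, compound 2 therefore stands at the lowest of the two numbers in this assay, with compound 1 its only neighbour at a gap within the scatter.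

Compound 3 `COc1cc(C(=O)/C=C/c2ccc(Br)cc2)cc(OC)c1OC` has not yet been measured. It differs from compound 2 by the change (4-bromophenyl in place of 3,4-dihydroxyphenyl on a double-bonded chain carbon bound to a double-bonded chain carbon). Among the measured compounds shown here, the one measured step, from compound 1 to compound 2, bears on this only in part: it covers the loss of one hydroxy group, and it was within the scatter. For the measured compounds named here, no measured step covers the bromine that enters, so its effect is unknown. On this basis a step beyond the scatter in this assay is not expected in either direction, and compound 3 is estimated to move by a 1.3-fold higher number from compound 2 to compound 3 (0.10 log units; within the scatter). For compound 3 in this assay the expected number is 25000 nM, with a range from 8000 nM to 80000 nM.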

Compound 3, half-maximal inhibitory concentration: 22500 nM
The estimate for compound 3 lay 1.1-fold (0.05 log units) above the measured number; low and high end bracket the measured number.
By their numbers in this assay, from the lowest: compounds 2, 3 and 1 (each within the scatter of the next).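

In this assay, 4-bromophenyl in place of 3,4-dihydroxyphenyl on a double-bonded chain carbon bound to a double-bonded chain carbon gives a 1.1-fold higher number from compound 2 to compound 3 (0.06 log units; within the scatter), so this exchange, in which the entering group has 0 hydrogen-bond donors and 0 hydrogen-bond acceptors, produces no step beyond the scatter. Among these compounds, the single exchange of bromo in place of hydroxy on an aromatic carbon likewise gives a 1.3-fold lower number from compound 1 to compound 3 (0.12 log units; within the scatter), which means that none of the three aryl groups now measured at this place can be ordered against the next, and the earlier hydroxy step no longer stands alone as a small change here. No measurement on these compounds offers an explanation for this result.

On these data alone, whether any group at this place can produce a step beyond the scatter remains open, for instance an amine or a carboxylic acid on the aromatic ring in place of the bromo. Also open, as far as these compounds go, is whether the same lack of separation would hold with a longer chain between the carbonyl and the aromatic ring, or on cells of another kind.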